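A few compounds are considered here, and "the series" means these few. Any claim that something is new, unique, unknown or untested is made for them only; others in the source may bear on it.

Compound 1 `Cc1cc(C)cc(SCc2ccc(/C=C/C(=O)Nc3ccccc3N)cc2)c1` stands at the bottom of the three numbers in hand: in a functional assay on A-375 cells (Homo sapiens) for inhibition, read by CCK-8 assay, with a stated time of 72 h, tested at 8 uM (a lower number here means less inhibition of growth, a higher number more inhibition of growth at the concentration tested), compound 1 gives 2.49%. Compound 3 `Nc1ccccc1NC(=O)/C=C/c1ccc(CSc2ccc(C(F)(F)F)cn2)cc1` gives 3.96% in this assay and lies within the scatter of compound 1, while compound 2 `COc1ccc(SCc2ccc(C(=O)Nc3ccccc3N)cc2)cc1` gives 81.8% in this assay, far beyond it; compound 2 differs from compound 1 in more than one place, so the two values can only be set side by side. The change from compound 1 to compound 4 `Cc1ccc(SCc2ccc(/C=C/C(=O)Nc3ccccc3N)cc2)cc1` is 4-methylphenyl in place of 3,5-dimethylphenyl on a sulfur. Among the compounds with values here, the one measured step that bears on it is the other exchange of the aryl group on the same sulfur, a number 1.5 percentage points higher from compound 1 to compound 3 (within the scatter), which lies within the scatter. Because a number 1.5 percentage points higher from compound 1 to compound 3 (within the scatter) stayed within the scatter, exchanging one aryl on this sulfur for another is expected to give no step beyond the scatter. The step from compound 1 to compound 4 is expected to be a number 2.5 percentage points higher from compound 1 to compound 4 (within the scatter). Compound 4 is therefore estimated at 5%, with a range from 0% to 20%.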

Compound 4, percent growth inhibition at one concentration: 31.2%
Estimate against measurement, compound 4: 26.2 percentage points below; measured number above the stated range.
By their numbers in this assay, from the lowest: compounds 1 and 3 (each within the scatter of the next); then compound 4; then compound 2.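

In this assay the aryl group on this sulfur is not a silent exchange: 4-methylphenyl in place of 3,5-dimethylphenyl gives a number 28.7 percentage points higher from compound 1 to compound 4 (beyond the scatter), and 4-methylphenyl in place of 5-(trifluoromethyl)pyridin-2-yl gives a number 27.2 percentage points higher from compound 3 to compound 4 (beyond the scatter). The earlier exchange, a number 1.5 percentage points higher from compound 1 to compound 3 (within the scatter), therefore does not hold for every aryl group at this place, and two close carbon-only aryl groups, differing by one methyl carbon and its placement, can read differently. Nothing in hand accounts for this gain.

As far as these compounds go, whether the step follows from the count of methyl groups or from their placement stays open, and plain phenyl on the same sulfur would help to separate the two. From the compounds shown here alone, how an aminophenyl or a carboxyphenyl would read at this place also remains open.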